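This account rests on a few compounds, and the source may have more. Where it says the series, first, only, none or still open, it means among the compounds named here.

Measured so far in an assay on isolated protein for binding affinity to vitamin D3 receptor (Homo sapiens), with a stated time of 4 h; on this read-out lower numbers stand for stronger inhibition and higher numbers for weaker inhibition:
compound 1, `C#CCNC(=O)c1ccc(C(CC)(CC)c2ccc(OCC(O)C(C)(C)C)c(C)c2)n1CC`: > 10000 nM, which is a limit of this assay.
compound 2, `CCn1c(C(=O)NCCN)ccc1C(CC)(CC)c1ccc(OCC(O)C(C)(C)C)c(C)c1`: 194 nM.

Among the measured compounds shown here, compound 2 holds the only number in this assay; the other value is a limit. The next compound, compound 3, `CCn1c(C(=O)N(CCC#N)CCC#N)ccc1C(CC)(CC)c1ccc(OCC(O)C(C)(C)C)c(C)c1`, changes the amide side: a group of 9 heavy atoms (6 carbon, 3 nitrogen; no ring) in place of a group of 4 heavy atoms (2 carbon, 2 nitrogen; no ring), on a carbonyl carbon, in words a group of 9 heavy atoms (6 carbon, 3 nitrogen; no ring) in place of a group of 4 heavy atoms (2 carbon, 2 nitrogen; no ring), on a carbonyl carbon. The (2-aminoethyl)amino group leaves, the amide hydrogen with it, and two triple bonds outside aromatic rings enter. For the measured compounds named here, the one measured step at this position, an at least 51-fold lower number from compound 1 to compound 2 (1.71 log units; beyond the scatter), was large and went toward stronger binding when an aminomethyl replaced an ethynyl. Compound 3 moves back toward a triple-bond-bearing, donor-free amide, so a large step toward a higher number is expected. Compound 3 may not yield a number at all, given (the limit of > 10000 nM in this assay, at which 1 of the 2 values shown sits). Compound 3 is expected at 3500 nM, with a range of 800 nM to 15000 nM. The expected step is an 18-fold higher number from compound 2 to compound 3 (1.26 log units; beyond the scatter).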

Compound 3, half-maximal inhibitory concentration: > 10000 nM
Compound 3: no number, only a limit (the forecaster's own chance of this, stated with the estimate: 40%); at least 2.8-fold (0.45 log units) between middle value and limit.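

In this assay, exchanging the whole (2-aminoethyl)amino group on the carbonyl carbon gives an at least 51-fold higher number from compound 2 to compound 3 (1.71 log units; beyond the scatter), so this position responds to a change of the full amide side as well as to the swap at the chain end seen earlier. The step between compound 1 and compound 3 cannot be read, since both values are limits, and the presence of the amide hydrogen in compound 1 and its absence in compound 3 therefore cannot be told apart here. Compound 2 remains the only compound with a number, and the limit now recurs at this position: the limit of > 10000 nM in this assay, at which 2 of the 3 values shown sit.

Compound 3 loses the amino group and the amide hydrogen and gains two nitrile-bearing chains in a single change, so the share of each in the step remains unresolved. Open too, as far as these compounds go, is whether the terminal amine itself matters or whether other groups on the same amide hydrogen-bearing chain would also give a number, such as a hydroxyl in place of the amine, a dimethylamino group or a longer 3-aminopropyl chain.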